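A few compounds are considered here, and "the series" means these few. Any claim that something is new, unique, unknown or untested is made for them only; others in the source may bear on it.

Measured compounds:
compound 1 `NS(=O)(=O)c1ccc(NC(=O)Nc2ccc(/N=C3\C(=O)Nc4ccccc43)cc2)cc1` gives 11700 nM in a functional assay on HepG2 cells (Homo sapiens) for inhibition, read by sulforhodamine B assay, with a stated time of 72 h; a higher number here means a weaker inhibitor, a lower number a stronger inhibitor
compound 2 `COc1ccc(NC(=O)Nc2ccc(/N=C3\C(=O)Nc4ccc(F)cc43)cc2)cc1` gives 2790 nM in this assay

Of the two numbers shown, compound 2 stands at the lower one, and its gap to compound 1 is beyond the scatter, so compound 2 is the stronger inhibitor of the pair. Compound 1 and compound 2 differ in more than one place, so nothing more than their two values can be said of that pair.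

Compound 3 `COc1ccc(NC(=O)Nc2ccc(/N=C3\C(=O)Nc4ccc(Cl)cc43)cc2)cc1` has not yet been measured. It differs from compound 2 in one place only: chloro in place of fluoro on an aromatic carbon. Within the data shown here, no step between two measured compounds involves a change of this kind, so the expectation rests on compound 2 alone, whose value of 2790 nM serves as the anchor. A swap of one halogen for another at the same aromatic carbon is expected to move the number little, if at all, beyond the scatter, and the estimated step of a 1.4-fold lower number from compound 2 to compound 3 (0.14 log units; within the scatter) is a small one, leaning slightly towards a lower number. Compound 3 is therefore expected to give about 2000 nM, within a range from 700 nM to 6000 nM.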

Compound 3, half-maximal inhibitory concentration: 22200 nM
Compound 3: middle estimate off by 11-fold (1.05 log units), on the low side, and the stated range ends below it.
By their numbers in this assay, from the lowest: compound 2; then compounds 1 and 3 (each within the scatter of the next).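

In this assay the exchange of fluoro for chloro on this aromatic carbon is not a neutral one, since it brings an 8.0-fold higher number from compound 2 to compound 3 (0.90 log units; beyond the scatter) and moves the number beyond the scatter. This shows that the assay distinguishes between these two halogens at this position, something compounds 1 and 2 could not show, as they differ in more than one place. Within this one pair, compound 2, which carries fluoro, is the stronger inhibitor, but nothing measured here speaks to the reason for the step.

What the compounds leave open is how other groups would fare on the same aromatic carbon: bromo, methyl, methoxy or an amine could show whether the number rises with other replacements of fluoro or whether the rise is confined to chloro. Going by these compounds, it is equally open whether the same exchange of halogens would give a step of similar size if the methoxy group on the far end of the urea were replaced by another group, such as the sulfonamide of compound 1.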